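The compounds below may be only part of what the source reports. "The series", "measured", "known", "first", "only" and "open" are said of these compounds alone.

Compound 1 `O=C(CCC1CCCCC1)Nc1ncc(C(=O)c2cccc3ccccc23)s1`: > 40000 nM
Compound 2 `O=C(Nc1ncc(Cc2cccc3ccsc23)s1)C1CCCCC1`: > 40000 nM

In an ADME assay on P388D1 cells (Mus musculus) for cytotoxicity, read by fluorescence and resazurin assay, with a stated time of 72 h (a lower number here means a stronger inhibitor, a higher number a weaker inhibitor), compound 2 gives > 40000 nM, which is a limit of the assay and not a number. Compound 1 gives > 40000 nM, which is also a limit. Compound 3 `O=C(CCC1CCCCC1)Nc1ncc(Cc2cccc3ccsc23)s1` has 2-cyclohexylethyl in place of the cyclohexyl of compound 2 on a carbonyl carbon: 2-cyclohexylethyl in place of cyclohexyl on a carbonyl carbon. Within the data shown here, no measured step shows the size of such a change, so no step beyond the scatter is expected in this assay. This expectation rests on (the limit of > 40000 nM in this assay, at which 2 of the 2 values shown sit). The expected change is a number no higher from compound 2 to compound 3 (the limit leaves the size open). The estimated value for compound 3 is 40000 nM, with an expected range of 15000 nM to 60000 nM.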

Compound 3, half-maximal inhibitory concentration: 18900 nM
Beside the measured number, compound 3's estimate is 2.1-fold (0.33 log units) above it; the range from low to high includes it.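

In this assay putting 2-cyclohexylethyl in place of cyclohexyl on a carbonyl carbon gives an at least 2.1-fold lower number from compound 2 to compound 3 (0.32 log units; beyond the scatter) and so shows that a change at this position can move the read-out. Compound 2 gives > 40000 nM as a limit of the assay and not a number, so only the smallest possible size of this step is known.

The compounds shown leave open whether a still longer chain on this carbonyl carbon would lower the number further. They also leave open what an amine or a carboxylic acid in that place would do.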